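Series notes: chloro in place of nitro, compound 4

The source may report more compounds than this note shows. Statements on the series, on what has been measured and on what is new or still open speak of the compounds shown alone.

Of the compounds shown here, three with a shared core have been tested in an assay on COS-7 cells for inhibition of Fatty-acid amide hydrolase 1 (Homo sapiens), read by scintillation counting, with a stated time of 10 min, tested at 10 uM; on this read-out lower numbers stand for less inhibition and higher numbers for more inhibition at the one concentration tested (going by the name of the read-out). Compound 1 `COc1nn(Cc2cccc([N+](=O)[O-])c2)c(=O)o1` gives 7%. Compound 2 `COc1nn(Cc2ccc([N+](=O)[O-])cc2)c(=O)o1` gives 18% in this assay. Compound 3 `COc1nn(Cc2ccccc2NC(=O)c2ccccc2)c(=O)o1` is reported in this assay as "not active" (no number reported), with no number attached. Of the two numbers available, compound 1 stands lowest, and the gap up to compound 2 lies beyond the usual scatter; compound 3 cannot be placed on this scale.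

Compound 4 `COc1nn(Cc2cccc(Cl)c2)c(=O)o1` has not been measured. It differs from compound 1 by chloro in place of nitro on an aromatic carbon. Going by the values given here, no pair of measured compounds shows this change, so its effect is not anchored by any step already in hand. Both numbers in the set are low and the third compound gives none, so only a small shift is expected; the step from compound 1 to compound 4 is estimated as a number 5 percentage points higher from compound 1 to compound 4 (within the scatter), not beyond the scatter. Compound 4 is expected to give about 12% in this assay, estimated to fall between 0% and 30%.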

Compound 4, a percentage reported as inhibition, at one concentration (the size of the read-out at that concentration, not a potency): 37%
Compound 4: the middle estimate sits 25 percentage points below what was measured, outside the stated range (above it).
By their numbers in this assay, from the lowest: compound 1; then compound 2; then compound 4.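

Chloro in place of nitro on an aromatic carbon, meta to a group of 9 heavy atoms, gives a number 30 percentage points higher from compound 1 to compound 4 (beyond the scatter) in this assay. Going by these compounds alone, the earlier compounds offered no step between measured neighbours, so this is the first sign that the group on this carbon alone can move the read-out beyond the scatter. Nothing in hand explains why this change has that effect.

On these data alone, whether the step reflects chloro entering or nitro leaving remains open, and so does whether the same change would carry over to any other carbon of the ring. As far as these compounds go, it is also open how fluoro, an amine or a carboxylic acid on this carbon would read, and a percentage at one concentration gives no potency for compound 4.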